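This account rests on a few compounds, and the source may have more. Where it says the series, first, only, none or still open, it means among the compounds named here.

Working notes on the series.

Two compounds have been run in an in vitro functional assay on cells for agonist activity at Bombesin receptor subtype-3 (Mus musculus), read by luminescence and calcium flux; a higher number here means that more compound is needed for the effect, a lower number that less compound is needed. Compound 1 `O=C(O)c1ccccc1-c1ccc(CCc2ncc(-c3ccccc3)[nH]2)cc1` gives 872 nM. Compound 2 `CC(C)(C)CCc1cnc(CCc2ccc(-c3ccccc3C(=O)O)cc2)[nH]1` gives 6.2 nM. Going by the values given here, the one step between them, a 140-fold lower number from compound 1 to compound 2 (2.15 log units; beyond the scatter), is the only measured change so far, and compound 2 thus stands with the lowest number of the two, with compound 1 as its sole neighbour at a markedly higher value.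

Compound 3 `N#Cc1ccccc1Cc1cnc(CCc2ccc(-c3ccccc3C(=O)O)cc2)[nH]1` is next, not yet measured. The change from compound 2 is 2-cyanophenyl in place of neopentyl on a saturated chain carbon bound to an aromatic carbon. It bears some resemblance to the measured step run backwards: a ring of the kind that compound 1 carries directly on the core comes in again, though here it sits on a saturated chain carbon and bears a nitrile. The step of a 140-fold lower number from compound 1 to compound 2 (2.15 log units; beyond the scatter) was large, so a move back toward an aromatic group is taken to cost something, while the retained chain carbon argues against a full return to the level of compound 1. The step from compound 2 is therefore expected to be an 8.1-fold higher number from compound 2 to compound 3 (0.91 log units; beyond the scatter). Compound 3 is estimated at 50 nM, with a range of 8 nM to 300 nM.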

Compound 3, half-maximal effective concentration: 642 nM
Compound 3: middle estimate off by 13-fold (1.11 log units), on the low side; the measured number lies above the stated range.
By their numbers in this assay, from the lowest: compound 2; then compounds 3 and 1 (each within the scatter of the next).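

In this assay the step of a 100-fold higher number from compound 2 to compound 3 (2.02 log units; beyond the scatter) shows that this place, on a saturated chain carbon bound to an aromatic carbon, does not accept 2-cyanophenyl in place of neopentyl without a large change, so keeping the saturated chain carbon is not enough to hold the low number of compound 2. The step of a 1.4-fold lower number from compound 1 to compound 3 (0.13 log units; within the scatter) lies within the scatter, so 2-cyanobenzyl and phenyl on an aromatic carbon cannot be told apart in this assay, and among the three compounds only 3,3-dimethylbutyl gives the low number. No measurement shown here bears on the reason for this result.

From the compounds shown here alone, it remains open whether the large step follows from the six-membered aromatic ring or from the nitrile, a question that a plain benzyl or a cyclohexylmethyl group at this place would help to separate. Also open, going by these compounds, is how much the branched end of 3,3-dimethylbutyl contributes, which a straight n-butyl or n-pentyl chain would test.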